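Propyl to ethyl on the nitrogen on an aromatic ring

This account rests on a few compounds, and the source may have more. Where it says the series, first, only, none or still open, it means among the compounds named here.

Measured in an assay on isolated protein for inhibition of leukotriene C4 synthase (Homo sapiens), read by LC-MS, with stated times of 45 min and 20 min; a higher number here means a weaker inhibitor, a lower number a stronger inhibitor:
compound 1 `COc1cc(N(CC(C)C)c2cccc(C(F)(F)F)c2)cnc1C(=O)[C@H]1C[C@@H]1C(=O)O` gives 20.6 nM
compound 3 `CCCN(c1cccc(C(F)(F)F)c1)c1cnc(C(=O)[C@H]2C[C@@H]2C(=O)O)c(OC)c1` gives 58.4 nM
compound 2 `COc1cc(N(CC(C)(C)O)c2cccc(C(F)(F)F)c2)cnc1C(=O)[C@H]1C[C@@H]1C(=O)O` is recorded as "not determined" (no result reported) in this assay, so no result is reported for it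

Compound 3 stands as the higher of the two numbers, the nearest being compound 1, and the step from the isobutyl of compound 1 to the propyl of compound 3 reads a 2.8-fold higher number from compound 1 to compound 3 (0.45 log units; beyond the scatter): hydrogen in place of methyl on a saturated chain carbon bound to two saturated chain carbons weakens by a modest amount that lies beyond the scatter.

Compound 4 `CCN(c1cccc(C(F)(F)F)c1)c1cnc(C(=O)[C@H]2C[C@@H]2C(=O)O)c(OC)c1` continues in the same direction: hydrogen in place of methyl on a saturated chain carbon, two bonds along the chain from a nitrogen on an aromatic ring. Within the data shown here, the only step that bears on it is the one from compound 1 to compound 3, which removed a methyl one bond further out along the same chain and gave a modest loss. Each carbon removed from this chain has so far cost potency, so a further loss of similar size is expected here rather than none, though a single precedent is a thin basis and the new cut sits closer to the ring nitrogen.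

For compound 4 the expected step is a 2.1-fold higher number from compound 3 to compound 4 (0.31 log units; beyond the scatter), giving an estimate of 120 nM with a range from 50 nM to 300 nM.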

Compound 4, half-maximal inhibitory concentration: 113 nM
Compound 4: the middle estimate sits 1.1-fold (0.03 log units) above what was measured, within the range that was stated.
By their numbers in this assay, from the lowest: compound 1; then compounds 3 and 4 (each within the scatter of the next).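

In this assay, cutting the propyl of compound 3 back to ethyl reads a 1.9-fold higher number from compound 3 to compound 4 (0.29 log units; within the scatter), so taken alone, removing a methyl at this place, two bonds along the chain from a nitrogen on an aromatic ring, cannot be told from no change. The difference shows only over the whole shortening, where methyl in place of isopropyl on the saturated chain carbon bound to that nitrogen reads a 5.5-fold higher number from compound 1 to compound 4 (0.74 log units; beyond the scatter), a separation that holds for the isobutyl and ethyl ends of the set while the propyl and ethyl compounds stay within the scatter of each other. No measured data bear on what lies behind these numbers.

With only isobutyl, propyl and ethyl to compare, chain length and branching on this nitrogen cannot be separated, and a straight butyl chain set against the isobutyl of compound 1 would address that directly. Also open, on these data alone, is how a cyclopropylmethyl group, a longer chain such as pentyl, or a bare hydrogen on the nitrogen would read in this assay.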